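Fluoro in place of hydrogen, carried to a second core

A few compounds are considered here, and "the series" means these few. Any claim that something is new, unique, unknown or untested is made for them only; others in the source may bear on it.

Compound 1 `CN(C)CCNc1nc(-c2ccc(NC(=O)Nc3ccccc3)cc2)nc2ccsc12` gives 1310 nM in a functional assay on MDA-MB-231 cells (Homo sapiens) for cytotoxicity, read by MTT assay, with a stated time of 72 h; on this read-out higher numbers stand for weaker inhibition and lower numbers for stronger inhibition. Compound 2 `CN(C)CCNc1nc(-c2ccc(NC(=O)Nc3ccccc3F)cc2)nc2ccsc12` differs from it by fluoro in place of hydrogen on an aromatic carbon and gives 600 nM in this assay; the step of a 2.2-fold lower number from compound 1 to compound 2 (0.34 log units; beyond the scatter) follows. Compound 3 `CCN(CC)CCCNc1nc(-c2ccc(NC(=O)Nc3ccccc3)cc2)nc2c(Cl)c(Cl)sc12` gives 1780 nM in this assay; the difference between the core of compound 1 and the core of compound 3 is not broken down here, and the two values lie within the scatter of each other. Compound 4 `CCN(CC)CCCNc1nc(-c2ccc(NC(=O)Nc3ccc(F)cc3)cc2)nc2c(Cl)c(Cl)sc12` is not yet measured and differs from compound 3 by fluoro in place of hydrogen on an aromatic carbon. This is the same kind of change as that from compound 1 to compound 2, not the same: there the fluoro sits ortho to a large group, here para to a large group. Given a 2.2-fold lower number from compound 1 to compound 2 (0.34 log units; beyond the scatter), the expected step is a 1.5-fold lower number from compound 3 to compound 4 (0.17 log units; within the scatter), held smaller for the changed place. Compound 4 is estimated at 1200 nM, between 500 nM and 2800 nM.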

Compound 4, half-maximal inhibitory concentration: 1630 nM
Compound 4: middle estimate off by 1.4-fold (0.13 log units), on the low side; low and high end bracket the measured number.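

On the second core, in this assay, the same replacement gives a 1.1-fold lower number from compound 3 to compound 4 (0.04 log units; within the scatter), so no effect of the fluoro can be read on that core. Set beside the step on the first core, this does not establish a real difference between the two cores: the same change on two cores in this assay, a 2.2-fold lower number (0.34 log units; beyond the scatter) from compound 1 to compound 2 and a 1.1-fold lower number (0.04 log units; within the scatter) from compound 3 to compound 4, 2.0-fold (0.30 log units) apart, within the scatter of two such steps Nor does it show that the change carries over, since only one of the two steps lies beyond the scatter, and the cores, the amine side chains and the place of the fluoro all differ between the two pairs.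

Open, on these data alone, is how the step reads with the fluoro in the same place on both cores. Also open, as far as these compounds go, is whether a larger group on that phenyl ring, such as trifluoromethyl or methoxy, gives a step beyond the scatter on the core of compound 3.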